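Chloro to Hydrogen on the Shared Core: Compound 2 to 3

This account rests on a few compounds, and the source may have more. Where it says the series, first, only, none or still open, it means among the compounds named here.

Two compounds have numbers in a functional assay on NCI-H23 cells (Homo sapiens) for cytotoxicity, read by sulforhodamine B assay, with a stated time of 48 h; a higher number here means a weaker inhibitor of growth, a lower number a stronger inhibitor of growth. Compound 1 `ClCc1ccc(Cn2cnc3c(Cl)ncnc32)cc1` gives 660 nM in this assay. Among the measured compounds shown here, compound 2 `ClCc1ccccc1Cn1cnc2c(Cl)nc(Cl)nc21` gives 1510 nM in this assay; this is the highest of the two numbers, and its only neighbour is compound 1, whose number is lower by a margin beyond the scatter. For the measured compounds named here, the two differ in more than one place, so no single step between measured compounds is available.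

Compound 3 `ClCc1ccccc1Cn1cnc2c(Cl)ncnc21` is not yet measured in this assay. Relative to compound 2 it carries hydrogen in place of chloro on an aromatic carbon, hydrogen in place of chloro on an aromatic carbon. Going by the values given here, no measured pair isolates this change. Compound 1 carries a single chloro on the shared core and gives 660 nM, but it differs from compound 2 elsewhere as well, so its lower number cannot be assigned to one change alone. The expected step in this assay is therefore a modest fall, a 1.6-fold lower number from compound 2 to compound 3 (0.20 log units; within the scatter), not confidently beyond the scatter. For compound 3 the estimated value in this assay is 950 nM, with a range from 400 nM to 2300 nM.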

Compound 3, concentration for 50% growth inhibition: 2040 nM
For compound 3 the middle estimate is 2.1-fold (0.33 log units) below the measured one; measured number inside the range.
By their numbers in this assay, from the lowest: compound 1; then compounds 2 and 3 (each within the scatter of the next).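

In this assay, among the compounds shown here, the step at the ring carbon between two ring nitrogen atoms is the first single-place comparison: a 1.4-fold higher number from compound 2 to compound 3 (0.13 log units; within the scatter), so with this side chain the chloro and hydrogen at this position cannot be told apart. Compound 3 carries the same single chloro on the shared core as compound 1, yet compound 1 gives 660 nM and compound 3 gives 2040 nM, so the lower number of compound 1 does not follow from the loss of the chloro at this position alone. Nothing at hand bears on what lies behind this result.

The compounds shown give only chloro and hydrogen at this position, so it remains open whether an amine, a methoxy group or a longer chain there would move the number beyond the scatter. Also open, going by these compounds, is whether the same exchange would read the same way on the side chain of compound 1, where a second chloro on the shared core has no number here.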